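A few compounds are considered here, and "the series" means these few. Any claim that something is new, unique, unknown or untested is made for them only; others in the source may bear on it.

Compound 1 `ClCc1ccccc1Cn1cnc2c(Cl)nc(Cl)nc21`, compound 2 `ClCc1ccccc1Cn1cnc2c(Cl)ncnc21` and compound 3 `ClCc1ccccc1Cn1cnc2ncnc(Cl)c21` share a chloromethylbenzyl arm on closely related fused cores and were all examined in a functional assay on SW-620 cells (Homo sapiens) for cytotoxicity, read by sulforhodamine B assay, with a stated time of 48 h; on this read-out higher numbers stand for weaker inhibition of growth and lower numbers for stronger inhibition of growth. In this assay compound 1 gives 150 nM, compound 2 gives 1770 nM and compound 3 gives 2230 nM. Compound 2 and compound 3 are built from the same atoms joined differently; how their two cores differ is not broken down here, and their values in this assay lie close to each other. The change chloro in place of hydrogen on an aromatic carbon produced the step of a 12-fold lower number from compound 2 to compound 1 (1.07 log units; beyond the scatter), a large gain. Compound 4 `ClCc1ccccc1Cn1cnc2nc(Cl)nc(Cl)c21` arises from compound 3 by the same change, (chloro in place of hydrogen on an aromatic carbon), made on the core of compound 3 instead of that of compound 2. Compound 4 is expected to move by about an 8.9-fold lower number from compound 3 to compound 4 (0.95 log units; beyond the scatter), because the step of a 12-fold lower number from compound 2 to compound 1 (1.07 log units; beyond the scatter) was large and the starting points of the two cores sit near each other. Compound 4 is therefore estimated at 250 nM in this assay, most plausibly somewhere from 80 nM to 800 nM.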

Compound 4, concentration for 50% growth inhibition: 260 nM
For compound 4 the middle estimate is 1.0-fold (0.02 log units) below the measured one; the measured number falls inside the stated range.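

On the core of compound 3, chloro in place of hydrogen on an aromatic carbon between two ring nitrogen atoms gave, in this assay, an 8.6-fold lower number from compound 3 to compound 4 (0.93 log units; beyond the scatter). Set beside the same change on the other core, the two steps cannot be told apart in size, so in these two pairs the change carried over from one core to the other: the same change on two cores in this assay, a 12-fold lower number (1.07 log units; beyond the scatter) from compound 2 to compound 1 and an 8.6-fold lower number (0.93 log units; beyond the scatter) from compound 3 to compound 4, 1.4-fold (0.14 log units) apart, within the scatter of two such steps This rests on only two pairs in a single cell assay, so it does not show that the step would hold on a further core or in another assay, and it gives no reason for the lower numbers.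

The compounds shown carry only chloro or hydrogen at that aromatic carbon, which leaves open what an amine, a methoxy group or a methyl group there would give. Going by these compounds, the chloromethyl group of the benzyl arm is also the same throughout, so the effect of a hydroxymethyl or plain methyl group in its place remains open.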